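Bromine on the Core of a Polyphenol Inhibitor

The compounds below may be only part of what the source reports. "The series", "measured", "known", "first", "only" and "open" are said of these compounds alone.

Measured compounds:
compound 1, `Oc1ccc(/C=C/c2cc(O)c(O)c(O)c2)cc1O`: 3 ug/mL
compound 2, `O=C(c1cc(/C=C/c2ccc(O)cc2)cc(C(=O)c2cc(O)c(O)c(O)c2)c1)c1cc(O)c(O)c(O)c1`: 17.5 ug/mL

Of the compounds shown here, two have been measured in a functional assay; on this read-out higher numbers stand for weaker inhibition and lower numbers for stronger inhibition. Compound 1 gives 3 ug/mL, the lowest of the two numbers, while compound 2 gives 17.5 ug/mL, a higher number that lies beyond the usual scatter.

Compound 3, `Oc1cc(/C=C/c2cc(O)c(O)c(Br)c2)cc(O)c1O`, is not yet measured. It differs from compound 1 in one place: bromo in place of hydrogen on an aromatic carbon. Within the data shown here, no pair of measured compounds shows what this change does in this assay, so its size and direction are unknown. Nothing in the two measured numbers points to a large shift, and the expected step of no change at the digits printed from compound 1 to compound 3 (within the scatter) is small, within the scatter, with no clear direction. Compound 3 is therefore expected to give about 3 ug/mL, most likely between 1.2 ug/mL and 8 ug/mL.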

Compound 3, half-maximal inhibitory concentration: 8.1 ug/mL
Beside the measured number, compound 3's estimate is 2.7-fold (0.43 log units) below it, and the stated range ends below it.
By their numbers in this assay, from the lowest: compound 1; then compound 3; then compound 2.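

In this assay, the change of bromo in place of hydrogen on an aromatic carbon, ortho to a hydroxy group, brings a 2.7-fold higher number from compound 1 to compound 3 (0.43 log units; beyond the scatter), a modest step toward weaker inhibition. Among these compounds, this is the first direct reading of this position, and it shows that the position is not indifferent to what sits on it, yet compound 3 still inhibits with bromo in place. No measurement available here accounts for the shift.

A single replacement cannot show whether the loss belongs to bromine alone or would follow any group on this carbon; fluoro, methyl or methoxy in the same place would begin to separate those cases. An amine or a carboxylic acid there would test very different groups, and the same change on compound 2 remains an open question.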